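Methoxy in place of ethyl on a fused flavone core

A few compounds are considered here, and "the series" means these few. Any claim that something is new, unique, unknown or untested is made for them only; others in the source may bear on it.

Two compounds share one core and differ only at the group bound to the aromatic carbon flanked by two fluoro groups. Compound 1 `Cc1c(F)c(N)c2c(=O)cc(-c3ccc(N)c(F)c3)oc2c1F` gives 13 nM in a functional assay on MCF7 cells (Homo sapiens) for cytotoxicity, read by neutral red uptake, with a stated time of 3 days (a higher number here means a weaker inhibitor, a lower number a stronger inhibitor), and compound 2 `CCc1c(F)c(N)c2c(=O)cc(-c3ccc(N)c(F)c3)oc2c1F` gives 130 nM in the same assay, the higher of the two numbers shown, the change being a 10-fold higher number from compound 1 to compound 2 (1.00 log units; beyond the scatter). Compound 3 `COc1c(F)c(N)c2c(=O)cc(-c3ccc(N)c(F)c3)oc2c1F` is not yet measured; it carries methoxy in place of ethyl on an aromatic carbon. Within the data shown here, the only measured step that bears on this position is the one from compound 1 to compound 2, which shows that a small change at this carbon moves the number well beyond the scatter. Since methoxy resembles ethyl in size but brings an acceptor, an expected step of a 3.3-fold lower number from compound 2 to compound 3 (0.51 log units; beyond the scatter) is modest and downward, so compound 3 is estimated at 40 nM, within 10 nM to 200 nM.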

Compound 3, half-maximal inhibitory concentration: 100 nM
The estimate for compound 3 lay 2.5-fold (0.40 log units) below the measured number; measured number inside the range.
By their numbers in this assay, from the lowest: compound 1; then compounds 3 and 2 (each within the scatter of the next).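

In this assay, the exchange of ethyl for methoxy, each of 2 heavy atoms, gives a 1.3-fold lower number from compound 2 to compound 3 (0.11 log units; within the scatter), so the hydrogen-bond acceptor that methoxy adds at this aromatic carbon does not separate the two groups here. The new compound also stands apart from the methyl compound, with a 7.7-fold higher number from compound 1 to compound 3 (0.89 log units; beyond the scatter), so among these three compounds methyl alone holds the low number, and the earlier pair could not show that this gap is shared by a second, oxygen-bearing group. Nothing measured here bears on why the numbers fall this way.

Whether the gap follows the size of the group or something else stays open, as only three groups are shown at this carbon. A hydroxy group, a chloro group or a propyl chain there could fall with methyl, with ethyl and methoxy, or apart from both.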